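A few compounds are considered here, and "the series" means these few. Any claim that something is new, unique, unknown or untested is made for them only; others in the source may bear on it.

Measured in a functional assay on NCI-H1299 cells (Homo sapiens), read by flow cytometry; a higher number here means that more compound is needed for the effect, a lower number that less compound is needed:
- Compound 1 `N#Cc1ncc2nc1OCC/C=C\COc1ccc(Cl)cc1NC(=O)N2`: > 10000 nM
- Compound 2 `N#Cc1ncc2nc1OCCCCCOc1ccc(Br)cc1NC(=O)N2`: 10000 nM

The value for compound 1 is a limit of the assay and not a number. Going by the values given here, compound 2 gives 10000 nM, the only actual number so far. It stands level with the limit of > 10000 nM in this assay, at which 1 of the 2 values shown sits.

Compound 3 `N#Cc1ncc2nc1OCCCCCOc1ccc(CCO)cc1NC(=O)N2` keeps the core of compound 2 and carries 2-hydroxyethyl in place of bromo on an aromatic carbon. Among the compounds with values here, no measured pair shows what such an exchange does in this assay, so any expectation is loose. With compound 2 at 10000 nM, a reported number has little room to rise, and a modest move towards less compound needed is expected. The estimated change is a 2.0-fold lower number from compound 2 to compound 3 (0.30 log units; within the scatter). For compound 3 the expected value is 5000 nM, with an estimated range of 1500 nM to 10000 nM.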

Compound 3, half-maximal effective concentration: > 10000 nM
Compound 3 gave a limit, no number; the forecaster's own chance of this, stated with the estimate: 35%; middle value at least 2.0-fold (0.30 log units) from the limit.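

In this assay, putting 2-hydroxyethyl in place of bromo on an aromatic carbon, meta to a fused ring and para to a fused ring, gives a number no lower from compound 2 to compound 3 (the limit leaves the size open). This is the first step shown at this position, and it shows that this exchange, which brings in a hydrogen-bond donor and a hydrogen-bond acceptor, gives no gain over bromo in this read-out. The value of compound 3 is a limit of the assay and not a number, and it adds one more compound at that limit: the limit of > 10000 nM in this assay, at which 2 of the 3 values shown sit.

From the compounds shown here alone, how far compound 3 lies from compound 2 stays open. Also open, going by these compounds, is whether an amine, a carboxylic acid or a longer chain ending in hydroxyl on this carbon would bring the number down.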